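This account rests on a few compounds, and the source may have more. Where it says the series, first, only, none or still open, it means among the compounds named here.

For the measured compounds named here, compound 2 `COCCC1=C(N2CC2)C(=O)C(C)=C(N2CC2)C1=O` is one of two compounds measured so far, and in a functional assay on L1210 cells (Mus musculus), with a stated time of 12 days (a higher number here means a more potent compound, by a factor of ten per unit of this negative logarithm, a lower number a less potent compound), compound 2 gives 5.57, the lower of the two numbers. Compound 1 `CC1=C(N2CC2)C(=O)C(CC(C)OC(N)=O)=C(N2CC2)C1=O` gives 6.14 in this assay. Going by the values given here, only one measured step connects them: a number 0.57 log units lower from compound 1 to compound 2 (beyond the scatter), a change on the same side chain position that compound 3 now varies. Compound 3 `CC1=C(N2CC2)C(=O)C(C(C)C)=C(N2CC2)C1=O` differs from compound 2 by isopropyl in place of 2-methoxyethyl on a double-bonded ring carbon. Among the compounds with values here, no measured pair mirrors this exact exchange, so the one step that bears on it is the modest fall seen between compound 1 and compound 2 when the side chain was altered. Because that step was a number 0.57 log units lower from compound 1 to compound 2 (beyond the scatter), a further small drop or no change beyond the scatter seems the most likely outcome. A slight step down is expected, a number 0.12 log units lower from compound 2 to compound 3 (within the scatter). Compound 3 is therefore estimated at 5.45, within a range from 4.9 to 6.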

Compound 3, logarithm of the reciprocal of the active concentration, log(1/C): 5.6
Beside the measured number, compound 3's estimate is 0.15 log units below it, and the stated range covers the measured number.
By their numbers in this assay, from the lowest: compounds 2 and 3 (each within the scatter of the next); then compound 1.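

Putting isopropyl in place of 2-methoxyethyl on this double-bonded ring carbon gives a number 0.03 log units higher from compound 2 to compound 3 (within the scatter) in this assay, so this assay does not separate these two groups, although only 2-methoxyethyl carries a hydrogen-bond acceptor. The side chain of compound 1 remains the one that stands apart, with a number 0.54 log units lower from compound 1 to compound 3 (beyond the scatter), and this shows that the result for compound 2 was not peculiar to 2-methoxyethyl. Nothing available explains either step, and no independent measurement bears on them.

Going by these compounds, what stays open is which part of the side chain of compound 1 goes with its higher number. It is also unknown whether a primary amine, a carboxylic acid or a longer chain such as n-butyl at this position would sit with compound 2 and compound 3 or nearer compound 1.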